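Sulfur-linked aryl variation in a benzamide series

The compounds below may be only part of what the source reports. "The series", "measured", "known", "first", "only" and "open" are said of these compounds alone.

Of the compounds shown here, three have been measured in a functional assay on A-375 cells (Homo sapiens) for inhibition, read by CCK-8 assay, with a stated time of 72 h, tested at 2 uM; on this read-out higher numbers stand for more inhibition of growth at the one concentration tested and lower numbers for less inhibition of growth. Compound 1 `COc1ccc(SCc2ccc(/C=C/C(=O)Nc3ccccc3N)cc2)cc1OC` gives 46%, compound 2 `COc1ccc(SCc2ccc(C(=O)Nc3ccccc3N)cc2)cc1` gives 10.2% and compound 3 `Nc1ccccc1NC(=O)/C=C/c1ccc(CSc2cccc3ccccc23)cc1` gives 1.55% in this assay. Compound 2 stands second highest of the three numbers, within the scatter of compound 3 and well below compound 1. Among the measured compounds shown here, the only step measured so far, a number 44.5 percentage points lower from compound 1 to compound 3 (beyond the scatter), exchanges the aryl group on the sulfur and is large, with a naphthalen-1-yl in place of 3,4-dimethoxyphenyl.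

Compound 4 `Cc1cc(C)cc(SCc2ccc(C(=O)Nc3ccccc3N)cc2)c1` is the next compound to be measured in this assay. Its difference from compound 2 is 3,5-dimethylphenyl in place of 4-methoxyphenyl on a sulfur. This change also touches the aryl group on the sulfur, so the step from compound 1 to compound 3 is the only one that bears on it, and it points to a large loss when that group is altered. Compound 2, however, already sits near the bottom of the range, leaving little room for a further drop beyond the scatter. The step expected for compound 4 is therefore small, with a number 3.2 percentage points lower from compound 2 to compound 4 (within the scatter) as the estimated change. In this assay compound 4 is expected to give about 7%, with a likely range from 0% to 22%.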

Compound 4, percent growth inhibition at one concentration: 48.5%
For compound 4 the middle estimate is 41.5 percentage points below the measured one, and the stated range ends below it.
By their numbers in this assay, from the lowest: compounds 3 and 2 (each within the scatter of the next); then compounds 1 and 4 (each within the scatter of the next).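

In this assay, the change on the sulfur gives a number 38.3 percentage points higher from compound 2 to compound 4 (beyond the scatter), so a low value at this position with 4-methoxyphenyl does not set a limit for the aryl groups that can stand there. Read beside a number 44.5 percentage points lower from compound 1 to compound 3 (beyond the scatter), which belongs to a different core, this shows that exchanging the aryl group on the sulfur can move the read-out strongly in either direction, and a single direction for such changes cannot be assumed across the two pairs. The exchange keeps the heavy-atom count and the single six-membered aromatic ring while removing the oxygen and its hydrogen-bond acceptor, but nothing available accounts for the rise.

The pair cannot separate the gain of the methyl groups from the loss of the methoxy group, and 4-methylphenyl or 3,5-dimethoxyphenyl on the sulfur would bear directly on that question. As far as these compounds go, it also remains open whether 3,5-dimethylphenyl would give a similar result on the core of compound 1, and whether larger or more polar groups, such as 3,5-dichlorophenyl or an aminophenyl, would be tolerated at this position.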